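A few compounds are considered here, and "the series" means these few. Any claim that something is new, unique, unknown or untested is made for them only; others in the source may bear on it.

Measured compounds:
compound 1, `CCc1ccc(/C=C(\C#N)C(=O)O)cc1`, 500 nM
compound 2, `N#C/C(=C\c1ccc(Cl)cc1)C(=O)O`, 500 nM

In an assay on RBE4 cells for inhibition of Monocarboxylate transporter 1 (Rattus norvegicus), with a stated time of 15 min (on this read-out higher numbers stand for weaker inhibition and lower numbers for stronger inhibition), compound 1 gives 500 nM. In this assay compound 2 gives 500 nM, so compound 2 stands level with compound 1 at the digits shown; the single step measured so far, no change at the digits printed from compound 1 to compound 2 (within the scatter), brought no change beyond the scatter. Compound 3, `N#C/C(=C\c1ccc(Br)cc1)C(=O)O`, has not yet been measured. It differs from compound 2 by bromo in place of chloro on an aromatic carbon. For the measured compounds named here, the only measured step that bears on this change is no change at the digits printed from compound 1 to compound 2 (within the scatter), where a chloro group replaced an ethyl group on that aromatic carbon without an effect beyond the scatter. A bromo group on the same aromatic carbon is therefore expected to give a step in this assay of no size beyond the scatter, estimated as no change at the digits printed from compound 2 to compound 3 (within the scatter). Compound 3 is accordingly estimated at 500 nM, with a range from 200 nM to 1200 nM.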

Compound 3, half-maximal inhibitory concentration: 500 nM
Estimate against measurement, compound 3: no gap at the digits printed; low and high end bracket the measured number.
By their numbers in this assay, from the lowest: compounds 1, 2 and 3 (each within the scatter of the next).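

In this assay, bromo in place of chloro on the aromatic carbon gives no change at the digits printed from compound 2 to compound 3 (within the scatter), and bromo in place of ethyl gives no change at the digits printed from compound 1 to compound 3 (within the scatter). For the compounds shown here, the position para to a group of 7 heavy atoms has now taken ethyl, chloro and bromo with no difference beyond the scatter, so the absence of a step seen with the single earlier exchange extends to a second halogen and to a third group. Nothing measured here offers an explanation for this flat result.

The compounds shown leave open whether an amine, a hydroxyl group or a longer chain such as hexyl on this aromatic carbon would also leave the value unchanged. They also do not tell whether a bromo group on another carbon of the ring would behave in the same way.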